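A halogen swap on the phenoxy ring, step to compound 4

The compounds below may be only part of what the source reports. "The series", "measured", "known", "first", "only" and "open" are said of these compounds alone.

Three compounds share one core and differ in the halogen on a phenoxy ring. Compound 1 `Cc1nn(C)c(Oc2ccc(Cl)cc2)c1/C=N\CCCCCOc1cc2oc(=O)cc(C)c2cc1Cl` gives 18700 nM in a functional assay on U-87MG ATCC cells for antiproliferative activity against U-87 MG (Homo sapiens), read by MTT assay, with a stated time of 72 h; on this read-out higher numbers stand for weaker inhibition and lower numbers for stronger inhibition; compound 2 `Cc1nn(C)c(Oc2ccc(Br)cc2)c1/C=N\CCCCCOc1cc2oc(=O)cc(C)c2cc1Cl` gives 15300 nM; compound 3 `Cc1nn(C)c(Oc2ccc(F)cc2)c1/C=N\CCCCCCOc1cc2oc(=O)cc(C)c2cc1Cl` gives 16700 nM. All three numbers lie within the scatter of one another, so compound 3 stands on a level with the others. Going by the values given here, the only single step measured here is a 1.2-fold lower number from compound 1 to compound 2 (0.09 log units; within the scatter). Compound 4 `Cc1nn(C)c(Oc2cccc(Cl)c2)c1/C=N\CCCCCCOc1cc2oc(=O)cc(C)c2cc1Cl` carries 3-chlorophenyl in place of 4-fluorophenyl on an oxygen on an aromatic ring. Among the compounds with values here, that step also moves the halogen to another position, which no measured pair covers, so the expectation rests on the within-scatter step from compound 1 to compound 2. The expected step from compound 3 to compound 4 is a 1.0-fold higher number from compound 3 to compound 4 (0.01 log units; within the scatter), none beyond the scatter. Compound 4 is therefore estimated at 17000 nM, with a range from 8000 nM to 36000 nM.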

Compound 4, half-maximal inhibitory concentration: 8460 nM
For compound 4 the middle estimate is 2.0-fold (0.30 log units) above the measured one; the range from low to high includes it.
By their numbers in this assay, from the lowest: compounds 4, 2, 3 and 1 (each within the scatter of the next, the first and the last beyond it).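

Going by these compounds alone, putting 3-chlorophenyl in place of 4-fluorophenyl on this oxygen gives a 2.0-fold lower number from compound 3 to compound 4 (0.30 log units; within the scatter) and so stays level with the earlier compounds. Unlike the bromo-for-chloro step, this change alters both the halogen and its place on the ring, and the phenoxy position accepts the two changes together without a step beyond the scatter. Nothing measured here offers an explanation for this step.

The share of each change cannot be separated, as 3-fluorophenyl and 4-chlorophenyl are not among the compounds shown on this chain. Going by these compounds, how a methoxy group, an amine or a carboxylic acid on this ring would read also remains open.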